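Lengthening a Branched Chain at the Same Place

The source may hold more compounds than are shown below. What is called first, only, known or untested is meant among the compounds shown, and "the series" means these compounds.

Within the data shown here, compound 2 `CC(C)C(C)(C)/N=C(\NC#N)Nc1ccncc1` stands at the higher of the two numbers known so far: in a functional assay on the whole organism (blood, strain Wistar-Okamoto) with Rattus norvegicus as the target, with a stated time of 5 days (on this read-out higher numbers stand for an effect only at larger amounts of compound and lower numbers for an effect already at smaller amounts), compound 2 gives 20 mg/kg, while compound 1 `CC(C)(C)/N=C(\NC#N)Nc1ccncc1` gives 2.5 mg/kg. The change leading to compound 3 `CC(C)CC(C)(C)/N=C(\NC#N)Nc1ccncc1` is isobutyl in place of isopropyl on a saturated chain carbon bound to a double-bonded nitrogen and two saturated chain carbons. Among the measured compounds shown here, the only step known at that place, an 8.0-fold higher number from compound 1 to compound 2 (0.90 log units; beyond the scatter), also enlarged the group there and raised the number. A further, smaller rise, a 1.5-fold higher number from compound 2 to compound 3 (0.18 log units; within the scatter), is therefore expected, though it may not reach beyond the scatter. Compound 3 is estimated at 30 mg/kg, within a range from 10 mg/kg to 90 mg/kg.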

Compound 3, minimum effective dose: 20 mg/kg
The estimate for compound 3 lay 1.5-fold (0.18 log units) above the measured number, and the stated range covers the measured number.
By their numbers in this assay, from the lowest: compound 1; then compounds 2 and 3 (each within the scatter of the next).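

Going from isopropyl to isobutyl at this place brings no change at the digits printed from compound 2 to compound 3 (within the scatter) and so the rise seen at the earlier enlargement does not continue with this further chain carbon. Compared with compound 1, the larger group still leaves an 8.0-fold higher number from compound 1 to compound 3 (0.90 log units; beyond the scatter) and the number stays on the high side. No measured evidence is at hand to explain this level stretch.

From the compounds shown here alone, whether a longer chain or a cyclohexyl ring at this place would keep the number level or move it stays open. So does whether a hydroxyl on the chain would bring it back down.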